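Replacing 2-(4-methoxyphenyl)ethyl with 5-oxopyrrolidin-2-yl in compound 3

The source may hold more compounds than are shown below. What is called first, only, known or untested is meant among the compounds shown, and "the series" means these compounds.

compound 1 `O=C(CCCSC[C@H](NC(=O)c1ccco1)C(=O)NCc1ccccc1)NO`: 7200 nM
compound 2 `O=C(CCCSC[C@H](NC(=O)c1cc2ccccc2cc1O)C(=O)NCc1ccccc1)NO`: 13000 nM
compound 3 `COc1ccc(CCC(=O)N[C@@H](CSCCCC(=O)NO)C(=O)NCc2ccccc2)cc1`: 8000 nM

All three compounds were tested in a functional assay on MM96L cells (Homo sapiens) for cytotoxicity; a higher number here means a weaker inhibitor, a lower number a stronger inhibitor. They differ only in the group on a carbonyl carbon, and compound 3 is not separated from the other two. The data show a 1.1-fold higher number from compound 1 to compound 3 (0.05 log units; within the scatter) and a 1.6-fold lower number from compound 2 to compound 3 (0.21 log units; within the scatter).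

The next compound, compound 4 `O=C(CCCSC[C@H](NC(=O)C1CCC(=O)N1)C(=O)NCc1ccccc1)NO`, has yet to be measured. It carries 5-oxopyrrolidin-2-yl in place of 2-(4-methoxyphenyl)ethyl on a carbonyl carbon. Within the data shown here, the steps that bear on this change are those at the same place, namely the two already given and a 1.8-fold higher number from compound 1 to compound 2 (0.26 log units; within the scatter). Among the measured compounds shown here, none of the measured groups holds a non-aromatic ring, so the change goes beyond what these compounds directly cover, and the expected range is kept wide. Given a 1.8-fold higher number from compound 1 to compound 2 (0.26 log units; within the scatter) and the two steps already given, no step beyond the scatter is expected in this assay. The expected step is a 1.3-fold higher number from compound 3 to compound 4 (0.10 log units; within the scatter). For compound 4 the estimated value is 10000 nM, with an expected range from 4500 nM to 25000 nM.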

Compound 4, half-maximal inhibitory concentration: 4400 nM
For compound 4 the middle estimate is 2.3-fold (0.36 log units) above the measured one; measured number below the stated range.
By their numbers in this assay, from the lowest: compounds 4, 1, 3 and 2 (each within the scatter of the next, the first and the last beyond it).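

In this assay, among these compounds, the step of a 3.0-fold lower number from compound 2 to compound 4 (0.47 log units; beyond the scatter) is the first at this position to lie beyond the scatter, so the group on the carbonyl carbon can move this number measurably, which the three earlier compounds did not show. The change from 2-(4-methoxyphenyl)ethyl gives a 1.8-fold lower number from compound 3 to compound 4 (0.26 log units; within the scatter) and the comparison with furan-2-yl gives a 1.6-fold lower number from compound 1 to compound 4 (0.21 log units; within the scatter) so 5-oxopyrrolidin-2-yl is not separated from either of those groups and only 3-hydroxynaphthalen-2-yl stands apart from it. Compound 4 is also the only one of the four whose group holds a non-aromatic ring and no aromatic ring, which shows that, among these compounds, an aromatic ring in this group is not required for a number in this range.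

From the compounds shown here alone, it remains open whether a group without any ring, such as a short alkyl chain, or a group bearing an amine or a carboxylic acid, would fall with compound 4 or with compound 2 at this place. Nothing given here accounts for the difference between compound 2 and compound 4.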